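This account rests on a few compounds, and the source may have more. Where it says the series, first, only, none or still open, it means among the compounds named here.

Measured in a functional assay on A549 cells (Homo sapiens) for inhibition, read by sulforhodamine B assay, with a stated time of 48 h; a higher number here means a weaker inhibitor, a lower number a stronger inhibitor:
- Compound 1 `O=C(Nc1ccc(C(=O)NO)cc1)Nc1ccc(Cl)c(C(F)(F)F)c1`: 7200 nM
- Compound 2 `O=C(CCCC(=O)Nc1ccc(NC(=O)Nc2ccc(Cl)c(C(F)(F)F)c2)cc1)NO`: > 10000 nM

Compound 2 stands at > 10000 nM, which is a limit of this assay and not a number.

The next structure is compound 3 `O=C(/C=C/c1ccc(NC(=O)Nc2ccc(Cl)c(C(F)(F)F)c2)cc1)NO`. On an aromatic carbon of a six-membered aromatic ring of carbon only, para to a large group, 2-(hydroxycarbamoyl)ethenyl takes the place of ((3-(hydroxycarbamoyl)propyl)carbonyl)amino (2-(hydroxycarbamoyl)ethenyl in place of ((3-(hydroxycarbamoyl)propyl)carbonyl)amino on an aromatic carbon).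

Among the measured compounds shown here, one measured step bears on this change: an at least 1.3-fold higher number from compound 1 to compound 2 (0.14 log units; that floor lies within the scatter). It brought in the same group that now leaves, in place of hydroxycarbamoyl. Its size is only a floor, and it does not clearly separate the two compounds.

Compound 3 keeps a hydroxycarbamoyl group, as compound 1 does, with an ethenyl unit added. For the measured compounds named here, compound 1, at 7200 nM, is therefore the only true number to lean on, and a value near it is expected.

The expected change is an at least 2.0-fold lower number from compound 2 to compound 3 (0.30 log units; that floor lies within the scatter), towards a lower number, meaning a stronger inhibitor. For compound 3 the estimated value is 5000 nM, with an expected range from 1500 nM to 15000 nM.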

Compound 3, half-maximal inhibitory concentration: 3400 nM
Compound 3: the middle estimate sits 1.5-fold (0.17 log units) above what was measured; the measured number falls inside the stated range.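

In this assay, this position now shows a change that clears the scatter: 2-(hydroxycarbamoyl)ethenyl in place of hydroxycarbamoyl gives a 2.1-fold lower number from compound 1 to compound 3 (0.33 log units; beyond the scatter), a modest step, whereas the earlier step at this position did not clearly separate its two compounds. The same group in place of ((3-(hydroxycarbamoyl)propyl)carbonyl)amino gives an at least 2.9-fold lower number from compound 2 to compound 3 (0.46 log units; beyond the scatter), so the group on this aromatic carbon, para to a large group, gives a lower number than either of the other two groups tried here, though all three carry a hydroxycarbamoyl end. Going by these compounds, compound 2 stands at a limit of the assay and not a number, so that second step is only a floor and its true size stays unknown: the limit of > 10000 nM in this assay, at which 1 of the 3 values shown sits.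

The compounds shown cannot say whether the double bond itself matters, which 2-(hydroxycarbamoyl)ethyl, the same chain without it, would test, or whether a longer chain ending in hydroxycarbamoyl would push the number further down. They also leave open how much depends on the hydroxycarbamoyl end, since all three compounds keep it and none carries a carboxylic acid there instead.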